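Pyridin-2-yl in place of the sulfonylated pyrazole

A few compounds are considered here, and "the series" means these few. Any claim that something is new, unique, unknown or untested is made for them only; others in the source may bear on it.

Among the compounds with values here, compound 2 `CNC(=O)N1CCCc2ccc(NC(=O)c3ccc(-c4ccn(S(C)(=O)=O)n4)cc3)cc21` stands lowest of the two numbers measured so far in a functional assay on MV4-11 cells (Homo sapiens) for antiproliferative activity, with a stated time of 6 days, tested at 6.25 uM; on this read-out lower numbers stand for a weaker effect and higher numbers for a stronger effect at the one concentration tested: compound 2 gives 57.2%. Within the data shown here, its nearest neighbour is compound 1 `CNC(=O)N1CCCc2ccc(NC(=O)c3ccc(-c4ccn(C)n4)cc3)cc21`, which in this assay gives 97%; the single measured step, a number 39.8 percentage points lower from compound 1 to compound 2 (beyond the scatter), is beyond the scatter. Compound 3 `CNC(=O)N1CCCc2ccc(NC(=O)c3ccc(-c4ccccn4)cc3)cc21` is not yet measured. It differs from compound 2 by pyridin-2-yl in place of 1-(methylsulfonyl)-1H-pyrazol-3-yl on an aromatic carbon. Among the measured compounds shown here, no measured step covers this exchange directly; the only step that bears on it is the one from compound 1 to compound 2, which concerns the group on the aromatic nitrogen of the pyrazole, and compound 3 carries no such nitrogen substituent at all, the whole pyrazole leaving. Because compound 1 gives 97% while compound 2 gives 57.2%, the exchange is expected to lift the number back toward the upper end of the two. As far as these compounds go, the expected step is a number 27.8 percentage points higher from compound 2 to compound 3 (beyond the scatter), upward and beyond the scatter, though with wide uncertainty since the entering ring is untested. Compound 3 is estimated at 85%, with a range from 55% to 99%.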

Compound 3, a percentage reported as inhibition, at one concentration (the size of the read-out at that concentration, not a potency): 79.2%
Compound 3: the middle estimate sits 5.8 percentage points above what was measured; measured number inside the range.
By their numbers in this assay, from the lowest: compound 2; then compound 3; then compound 1.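

Pyridin-2-yl on this aromatic carbon, para to a large group, shows that the position in this assay does not depend on a pyrazole: replacing 1-(methylsulfonyl)-1H-pyrazol-3-yl gives a number 22 percentage points higher from compound 2 to compound 3 (beyond the scatter) with a six-membered aromatic ring of a single hetero atom in its place, while replacing 1-methyl-1H-pyrazol-3-yl gives a number 17.8 percentage points lower from compound 1 to compound 3 (beyond the scatter) at the same carbon. Ring size alone therefore does not set the order among the three compounds, since compound 3 falls between two five-membered rings that differ only in the group on the aromatic nitrogen. The data given here offer no explanation for either step, and each number remains a read-out at one concentration rather than a potency.

The compounds shown leave open how a plain phenyl ring, pyridin-3-yl or pyridin-4-yl would read at this position, and whether a methyl group or an amine on the pyridin-2-yl ring would bring the number closer to that of compound 1. As far as these compounds go, the rest of the core is the same in all three compounds, so whether these steps carry over to a different core also remains open.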